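Replacing 3-chloropropyl with (1H-benzimidazol-2-yl)sulfanyl

The source may report more compounds than this note shows. Statements on the series, on what has been measured and on what is new or still open speak of the compounds shown alone.

Measured in a functional assay on K562 cells (Homo sapiens) for cytotoxicity, read by MTT assay, with a stated time of 72 h; on this read-out lower numbers stand for stronger inhibition and higher numbers for weaker inhibition:
- compound 1 `C=C1C2=C(C(=O)N1OC)[C@H](OC(=O)CSc1nc3ccccc3o1)[C@@](C)(O)[C@H](CCCCC)O2`: 4500 nM
- compound 2 `C=C1C2=C(C(=O)N1OC)[C@H](OC(=O)CCCCCl)[C@@](C)(O)[C@H](CCCCC)O2`: 8500 nM

Within the data shown here, with only two measured compounds, the numbers offer little to build on. In this assay compound 2 gives 8500 nM, and this lies within the scatter of the value for compound 1, so the two cannot be told apart.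

The next compound is compound 3 `C=C1C2=C(C(=O)N1OC)[C@H](OC(=O)CSc1nc3ccccc3[nH]1)[C@@](C)(O)[C@H](CCCCC)O2`, which has (1H-benzimidazol-2-yl)sulfanyl in place of 3-chloropropyl on a saturated chain carbon bound to a carbonyl carbon.

Among the measured compounds shown here, one measured step bears on this change. It replaced the closely similar (1,3-benzoxazol-2-yl)sulfanyl with 3-chloropropyl, giving a 1.9-fold higher number from compound 1 to compound 2 (0.28 log units; within the scatter). Going back to a group of that kind should therefore give a step of similar size towards lower numbers, or none beyond the scatter. For the measured compounds named here, the nearest guide is compound 1 at 4500 nM, although no measurement yet compares these two sulfanyl groups directly.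

The estimate means a 1.7-fold lower number from compound 2 to compound 3 (0.23 log units; within the scatter). For compound 3 the expected value is 5000 nM, with an estimated range of 2000 nM to 12000 nM.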

Compound 3, half-maximal inhibitory concentration: 9300 nM
Beside the measured number, compound 3's estimate is 1.9-fold (0.27 log units) below it; the measured number falls inside the stated range.
By their numbers in this assay, from the lowest: compounds 1, 2 and 3 (each within the scatter of the next, the first and the last beyond it).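

In this assay, (1H-benzimidazol-2-yl)sulfanyl in place of 3-chloropropyl gives a 1.1-fold higher number from compound 2 to compound 3 (0.04 log units; within the scatter), so on a saturated chain carbon bound to a carbonyl carbon, a group of 10 heavy atoms with two aromatic rings cannot be told apart from a ringless group of 4 heavy atoms. The two sulfanyl groups can now be compared directly: 1H-benzimidazol-2-yl in place of 1,3-benzoxazol-2-yl on a sulfur gives a 2.1-fold higher number from compound 1 to compound 3 (0.32 log units; beyond the scatter), a modest step and the only one so far that lies beyond the usual scatter, so the ring group on the sulfur can make a small difference even though compound 2 cannot be separated from either sulfanyl compound. Nothing available explains the difference between these two ring groups.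

Going by these compounds, it remains open whether 1,3-benzothiazol-2-yl on the sulfur would stay within the scatter of compound 1 or of compound 3. On these data alone, it is also open whether a carboxylic acid, an amine or a longer chain in this place would produce a step larger than any seen here.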